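The compounds below may be only part of what the source reports. "The series", "measured", "known", "first", "only" and "open" are said of these compounds alone.

In a functional assay on the whole organism with Mus musculus as the target, in the writhing test (a lower number here means that less compound is needed, a higher number that more compound is needed for the effect), compound 1 `Clc1ccc2[nH]cc(SC3CCNCC3)c2c1` gives 0.3 mg/kg. In this assay compound 2 `CCCC(=O)N1CCC(Sc2c[nH]c3ccc(Cl)cc23)CC1` gives 8.9 mg/kg. In this assay compound 3 `Cc1[nH]c2ccc(F)cc2c1SC1CCNCC1` gives 5.9 mg/kg.

Compound 2 has the highest of the three numbers. Compound 3 lies close to it, within the usual scatter, so no order between these two can be claimed. Compound 1 stands far away: the step of a 30-fold higher number from compound 1 to compound 2 (1.47 log units; beyond the scatter) shows that attaching a propylcarbonyl to the ring amine nitrogen raised the number by a large margin.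

Compound 4 `CON1CCC(Sc2c[nH]c3ccc(Cl)cc23)CC1` has not yet been measured. It differs from compound 2 in one place: methoxy in place of propylcarbonyl on an amine nitrogen in a ring. Among the measured compounds shown here, only the step from compound 1 to compound 2 bears on this change, and it concerns the same nitrogen; it was large. A methoxy on that nitrogen is neither the propylcarbonyl of compound 2 nor the hydrogen of compound 1, so compound 4 is expected to fall between those two, nearer the higher number. The estimated step of a 3.6-fold lower number from compound 2 to compound 4 (0.55 log units; beyond the scatter) is therefore a moderate move toward a lower number. For compound 4 in this assay the expected value is 2.5 mg/kg, with a range from 0.6 mg/kg to 10 mg/kg.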

Compound 4, dose for half-maximal effect: 1.4 mg/kg
For compound 4 the middle estimate is 1.8-fold (0.25 log units) above the measured one; the range from low to high includes it.
By their numbers in this assay, from the lowest: compound 1; then compound 4; then compounds 3 and 2 (each within the scatter of the next).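

In this assay, the methoxy group on the ring amine nitrogen gives a 6.4-fold lower number from compound 2 to compound 4 (0.80 log units; beyond the scatter) and so recovers much of what the propylcarbonyl had lost in a 30-fold higher number from compound 1 to compound 2 (1.47 log units; beyond the scatter) on the same nitrogen, which shows that the size of the penalty at this position depends on the group placed there and that a substituent on this nitrogen need not cost as much as the propylcarbonyl did. Even so, hydrogen remains the best of the three groups compared here on this nitrogen, as a 4.7-fold higher number from compound 1 to compound 4 (0.67 log units; beyond the scatter) is a step beyond the scatter, so the order runs from hydrogen through methoxy to propylcarbonyl, with each step beyond the scatter. Nothing in the data given explains why these groups differ.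

The step from propylcarbonyl to methoxy changes the carbonyl and the length of the chain together, so the compounds shown cannot say which of the two matters. A plain methyl or a longer alkyl chain on this nitrogen, or an acetyl with its shorter chain, would separate the two, and compound 3 cannot help, as it differs from the others in more than one place.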